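The source may report more compounds than this note shows. Statements on the series, on what has been measured and on what is new or still open speak of the compounds shown alone.

Measured so far in a functional assay on MCF7 cells (Homo sapiens) for cytotoxicity, read by MTT assay, with a stated time of 72 h; a higher number here means a weaker inhibitor, a lower number a stronger inhibitor:

- compound 1, `Cc1cccc(/C(N)=N/NC(=S)N2CCSCC2)n1`: > 100000 nM, which is a limit of this assay and not a number
- compound 2, `Cc1cccc(/C(N)=N/NC(=S)N2CCOCC2)n1`: 21500 nM
- compound 3, `Cc1cccc(/C(N)=N/NC(=S)N2CCCCC2)n1`: 74000 nM

Compound 3 holds the higher of the two numbers given in this assay; its nearest neighbour is compound 2, the gap being a 3.4-fold higher number from compound 2 to compound 3 (0.54 log units; beyond the scatter). Compound 1 sits at the limit of > 100000 nM in this assay, at which 1 of the 3 values shown sits. From compound 1 the steps run as an at least 4.6-fold lower number from compound 1 to compound 2 (0.66 log units; beyond the scatter) and an at least 1.3-fold lower number from compound 1 to compound 3 (0.13 log units; that floor lies within the scatter), the latter with a floor inside the scatter, so compound 1 and compound 3 cannot be ordered on what is shown.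

Compound 4, `Cc1cccc(/C(N)=N/NC(=S)N2CCCC2)n1`, differs from compound 3 by pyrrolidin-1-yl in place of piperidin-1-yl on a thiocarbonyl carbon. Among the measured compounds shown here, none of the measured steps touches ring size: each swaps one six-membered ring for another, exchanging a ring hetero atom or removing it. The two steps beyond the scatter, an at least 4.6-fold lower number from compound 1 to compound 2 (0.66 log units; beyond the scatter) and a 3.4-fold higher number from compound 2 to compound 3 (0.54 log units; beyond the scatter), both involve morpholin-4-yl, which compound 4 lacks. The change here is of a different kind, so no direction can be read from them; the expected step in this assay is none beyond the scatter, a 1.1-fold lower number from compound 3 to compound 4 (0.02 log units; within the scatter), with wide uncertainty. Compound 4 is thus estimated at 70000 nM, within 25000 nM to 200000 nM.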

Compound 4, half-maximal inhibitory concentration: 61800 nM
Compound 4: the middle estimate sits 1.1-fold (0.05 log units) above what was measured; low and high end bracket the measured number.
By their numbers in this assay, from the lowest: compound 2; then compounds 4 and 3 (each within the scatter of the next). At a limit, above all of these: compound 1.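

In this assay, among the compounds shown here, this is the first change of ring size at this place, on a thiocarbonyl carbon, and it does not separate the two rings (a 1.2-fold lower number from compound 3 to compound 4 (0.08 log units; within the scatter)). For the compounds shown here, compound 2 keeps its distance from both rings that carry only the one ring nitrogen (a 2.9-fold higher number from compound 2 to compound 4 (0.46 log units; beyond the scatter) alongside a 3.4-fold higher number from compound 2 to compound 3 (0.54 log units; beyond the scatter)), so the gap seen for morpholin-4-yl does not depend on piperidin-1-yl as the partner, although compound 1 shows that a second ring hetero atom alone does not carry it (an at least 4.6-fold lower number from compound 1 to compound 2 (0.66 log units; beyond the scatter)). The step to compound 4 from compound 1 cannot be read, its floor lying inside the scatter (an at least 1.6-fold lower number from compound 1 to compound 4 (0.20 log units; that floor lies within the scatter)). Compound 1 gives a limit of the assay and not a number: the limit of > 100000 nM in this assay, at which 1 of the 4 values shown sits.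

Open, as far as these compounds go, is whether a piperazine ring or an open-chain diethylamino group on the thiocarbonyl carbon would fall with compound 2 or with compounds 3 and 4. Also open, from the compounds shown here alone, is whether the gap for morpholin-4-yl holds when the methyl group on the shared core is replaced by a chlorine atom.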